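The source may hold more compounds than are shown below. What is called first, only, known or untested is meant among the compounds shown, and "the series" means these compounds.

Working notes on the series.

Compound 3 `O=Cc1ccc(OCc2cn(-c3ccc(S(=O)(=O)N4CCc5ccccc5C4)cc3)nn2)cc1` stands at the limit of a functional assay on MOLT-3 cells (Homo sapiens) for cytotoxicity, read by MTT assay, with a stated time of 48 h; on this read-out lower numbers stand for stronger inhibition and higher numbers for weaker inhibition: compound 3 gives > 50 ug/mL, which is a limit of the assay and not a number. Compound 1 `Cc1ccccc1OCc1cn(-c2ccc(S(=O)(=O)N3CCc4ccccc4C3)cc2)nn1` likewise gives > 50 ug/mL in this assay, again a limit. Compound 2 `Cc1ccc(OCc2cn(-c3ccc(S(=O)(=O)N4CCc5ccccc5C4)cc3)nn2)cc1` gives > 50 ug/mL in this assay, also a limit. All three values sit at the same point, (the limit of > 50 ug/mL in this assay, at which 3 of the 3 values shown sit), so none of the steps among them can be read: a step that the two limits leave unreadable from compound 1 to compound 2, a step that the two limits leave unreadable from compound 1 to compound 3 and a step that the two limits leave unreadable from compound 2 to compound 3 are all unreadable in size.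

Compound 4 `O=S(=O)(c1ccc(-n2cc(COc3ccccc3)nn2)cc1)N1CCc2ccccc2C1` differs from compound 3 by hydrogen in place of formyl on an aromatic carbon. For the measured compounds named here, the steps that bear on it are the three above, and each of them is unreadable, so no size or direction can be taken from them for the change from compound 3 to compound 4. With every shown value at the limit, the expectation is that compound 4 also stays at or beyond the limit in this assay, and the step that the limit leaves unreadable from compound 3 to compound 4 is estimated to lie within the scatter. Compound 4 is therefore expected at about 60 ug/mL, with a range from 30 ug/mL to 120 ug/mL.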

Compound 4, half-maximal inhibitory concentration: > 50 ug/mL
Compound 4 was reported as a limit (the forecaster's own chance of this, stated with the estimate: 85%); the middle value lies beyond the limit too.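

In this assay compound 4 gives > 50 ug/mL, a limit of the assay and not a number. For the compounds shown here, no step from compound 1, compound 2 or compound 3 to compound 4 can be read: the limit of > 50 ug/mL in this assay, at which 4 of the 4 values shown sit. The compounds shown leave open how far beyond the limit each one lies, and whether any of these changes alters the value in this assay.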